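Replacing the (4-methylphenyl)amino group of compound 1

The source may report more compounds than this note shows. Statements on the series, on what has been measured and on what is new or still open speak of the compounds shown alone.

Compound 1 `Cc1ccc(Nc2nc(Cl)nc3c2ncn3Cc2ccc(C(=O)Nc3ccccc3N)cc2)cc1`: 860 nM
Compound 2 `CC(C)n1cnc2c(NCc3ccc(C(=O)Nc4ccccc4N)cc3)nc(Cl)nc21`: 3320 nM

Going by the values given here, in a functional assay on HepG2 cells (Homo sapiens) for antiproliferative activity, read by CCK-8 assay, with a stated time of 72 h (a higher number here means a weaker inhibitor, a lower number a stronger inhibitor), compound 1 holds the lower of the two numbers so far at 860 nM, and compound 2 gives 3320 nM. The gap between these two numbers lies beyond the usual scatter. Among the compounds with values here, these two compounds differ in more than one place, so no single-change step is available as a guide. Compound 3 `CC1CCN(c2nc(Cl)nc3c2ncn3Cc2ccc(C(=O)Nc3ccccc3N)cc2)CC1` keeps the core of compound 1 and carries 4-methylpiperidin-1-yl in place of (4-methylphenyl)amino on an aromatic carbon. In this assay, a moderate shift towards a higher number, meaning a weaker inhibitor, is expected, though the data cannot rule out a step within the scatter. The expected change is a 2.9-fold higher number from compound 1 to compound 3 (0.46 log units; beyond the scatter). Compound 3 is estimated at 2500 nM, with an expected range of 800 nM to 8000 nM.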

Compound 3, half-maximal inhibitory concentration: 5180 nM
For compound 3 the middle estimate is 2.1-fold (0.32 log units) below the measured one; low and high end bracket the measured number.
By their numbers in this assay, from the lowest: compound 1; then compounds 2 and 3 (each within the scatter of the next).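

In this assay, going by these compounds alone, the first single-change step in this set is a 6.0-fold higher number from compound 1 to compound 3 (0.78 log units; beyond the scatter), so this position on the shared core is not indifferent to the group it carries. The change swaps one six-membered ring for another of nearly the same size, yet it replaces an aromatic ring of carbon only with a non-aromatic ring holding one hetero atom, and it removes the hydrogen-bond donor, so the step reflects these differences together. Nothing measured here explains the step.

The compounds shown leave open whether the aromatic ring or the hydrogen-bond donor matters more at this position. A (4-methylcyclohexyl)amino group, which has a non-aromatic ring but keeps the amine hydrogen, would help separate the two.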